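This account rests on a few compounds, and the source may have more. Where it says the series, first, only, none or still open, it means among the compounds named here.

Working notes on the series. In a functional assay on NCI-H1975 cells (Homo sapiens) for antiproliferative activity, with a stated time of 72 h (a lower number here means a stronger inhibitor of growth, a higher number a weaker inhibitor of growth), compound 1 (`Cc1cccc(CN(C)C(=O)c2cc(Cl)c(O)cc2O)c1`) gives 49300 nM as its concentration for half growth inhibition, and compound 2 (`O=C(NCc1ccccc1)c1cc(Cl)c(O)cc1O`) gives 86200 nM on the same read-out. Among the measured compounds shown here, these two values lie within the scatter of each other, so compound 1 stands level with the only other measured compound, and no order can be drawn between them. Neither value marks a strong inhibitor of growth. For the measured compounds named here, no pair of measured compounds differs in one place only, so the series offers no measured step to lean on.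

Compound 3 (`Cc1ccc(CN(C)C(=O)c2cc(Cl)c(O)cc2O)cc1`) has the same atoms as compound 1, joined differently: 4-methylphenyl in place of 3-methylphenyl on a saturated chain carbon bound to an amide-type nitrogen is the whole change, with 4-methylphenyl in place of 3-methylphenyl on a saturated chain carbon bound to an amide-type nitrogen. Going by the values given here, nothing measured so far shows what such a shift does, so no step beyond the scatter is expected in this assay in either direction. The estimated move is a 1.0-fold higher number from compound 1 to compound 3 (0.01 log units; within the scatter) and so stays inside the scatter. Compound 3 is expected near 50000 nM on this read-out, within an estimated range of 20000 nM to 100000 nM at its two ends.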

Compound 3, concentration for 50% growth inhibition: 34300 nM
Compound 3: middle estimate off by 1.5-fold (0.16 log units), on the high side; low and high end bracket the measured number.
By their numbers in this assay, from the lowest: compounds 3, 1 and 2 (each within the scatter of the next, the first and the last beyond it).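

Among the compounds shown here, the swap of 4-methylphenyl in place of 3-methylphenyl on a saturated chain carbon bound to an amide-type nitrogen gives the first measured step, a 1.4-fold lower number from compound 1 to compound 3 (0.16 log units; within the scatter) in this assay. This step shows that, with the rest of compound 1 held constant, the two methylphenyl groups stand level on this read-out, and compound 3 at 34300 nM does not mark a strong inhibitor of growth either, so this exchange alone opens no measurable gap at this place. No measured evidence bears on the reason for this result.

As far as these compounds go, what stays open is whether a group of another kind on this ring, such as a carboxylic acid, a dimethylamino group or a longer alkyl chain in place of the methyl, would give a step beyond the scatter in this assay. Also open, from the compounds shown here alone, is whether the same exchange of methylphenyl groups would read the same with the amide hydrogen in place of the methyl on the amide-type nitrogen, or with another group in place of the chlorine on the shared core.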